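Swapping Fluorophenyl for Pyrrolyl on a Weak Growth Inhibitor

The source may report more compounds than this note shows. Statements on the series, on what has been measured and on what is new or still open speak of the compounds shown alone.

Compound 2 `CC1=CC[C@H](C(C)(C)NC(=S)N/N=C/c2ccc(F)cc2)CC1` was tested in a functional assay on U-251 cells (Homo sapiens) for inhibition, read by sulforhodamine B assay, with a stated time of 48 h; on this read-out higher numbers stand for weaker inhibition of growth and lower numbers for stronger inhibition of growth. In this assay compound 2 reached only the limit of the assay, > 100000 nM, so no number is known for it. Its close relative compound 1 `COc1ccc(/C=N/NC(=S)NC(C)(C)[C@H]2CC=C(C)CC2)cc1` gave 71900 nM in this assay. Among the measured compounds shown here, the one measured step, an at least 1.3-fold higher number from compound 1 to compound 2 (0.14 log units; that floor lies within the scatter), is small and is capped because the limit of > 100000 nM in this assay, at which 1 of the 2 values shown sits, sets the ceiling of what can be read. Compound 3 `CC1=CC[C@H](C(C)(C)NC(=S)N/N=C/c2ccc[nH]2)CC1` differs from compound 2 by 1H-pyrrol-2-yl in place of 4-fluorophenyl on a carbon with a double bond to nitrogen. For the measured compounds named here, no measured step touches that change, so the only guide is that compound 1 and compound 2 both sit at the weak end of this assay and lie within the scatter of one another. For compound 3 the expected step is therefore an at least 1.1-fold lower number from compound 2 to compound 3 (0.04 log units; that floor lies within the scatter), none beyond the scatter. Compound 3 is thus estimated at 90000 nM, with a range from 30000 nM to 300000 nM, and quite possibly again only a limit.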

Compound 3, concentration for total growth inhibition: 3900 nM
The estimate for compound 3 lay 23-fold (1.36 log units) above the measured number; measured number below the stated range.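

Compound 1 and compound 2 differ only in what the phenyl ring carries, and with both at the weak end of this assay, they gave no sign that this place could matter much. Changing the ring itself shows that it can: 1H-pyrrol-2-yl in place of 4-fluorophenyl gives an at least 25-fold lower number from compound 2 to compound 3 (1.40 log units; beyond the scatter), and in place of 4-methoxyphenyl it gives an 18-fold lower number from compound 1 to compound 3 (1.27 log units; beyond the scatter). The first of these steps is only a floor, because compound 2 stands at a limit and has no exact number: the limit of > 100000 nM in this assay, at which 1 of the 3 values shown sits.

The change from either phenyl ring to 1H-pyrrol-2-yl alters ring size, brings in a ring nitrogen and adds a hydrogen-bond donor all at once, so the compounds shown cannot say which of these goes with the stronger inhibition. A furan ring, or a pyrrole with a methyl on its ring nitrogen, would help to pull these apart.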